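The source may hold more compounds than are shown below. What is called first, only, known or untested is meant among the compounds shown, and "the series" means these compounds.

Compound 2 `COc1nc2ccc(Br)cc2cc1C(c1ccccc1)n1cc(-c2ccc(OC(F)(F)F)cc2)nn1` gives 11.7% in an ADME assay on PANC-1 cells (Homo sapiens) for cytotoxicity, read by sulforhodamine B assay, with a stated time of 48 h, tested at 10 uM (a lower number here means less inhibition, a higher number more inhibition at the concentration tested (going by the name of the read-out)), the lower of the two numbers measured; compound 1 `COc1nc2ccc(Br)cc2cc1C(c1ccccc1)n1cc(-c2ccccc2)nn1` gives 30.1%. For the measured compounds named here, the only measured step is a number 18.4 percentage points lower from compound 1 to compound 2 (beyond the scatter). Compound 3 `COc1nc2ccc(Br)cc2cc1C(c1ccccc1)n1cc(CO)nn1` differs from compound 2 by hydroxymethyl in place of 4-(trifluoromethoxy)phenyl on an aromatic carbon. The step from compound 1 to compound 2 bears only partly here, since the change from compound 2 to compound 3 removes the whole aryl group rather than just the trifluoromethoxy; the expected step is therefore a number 10.3 percentage points higher from compound 2 to compound 3 (beyond the scatter), upward but with wide uncertainty. For compound 3 the expected value is 22%, in the range 4% to 40%.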

Compound 3, a percentage reported as inhibition, at one concentration (the size of the read-out at that concentration, not a potency): 15%
For compound 3 the middle estimate is 7 percentage points above the measured one; the measured number falls inside the stated range.
By their numbers in this assay, from the lowest: compounds 2 and 3 (each within the scatter of the next); then compound 1.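

In this assay, this aromatic carbon of the five-membered ring carries a small non-ring group as well as an aryl group: hydroxymethyl gives a number 3.3 percentage points higher from compound 2 to compound 3 (within the scatter) and a number 15.1 percentage points lower from compound 1 to compound 3 (beyond the scatter). An aromatic ring at this place is therefore not required for a number in the range of compound 2, and among the three compounds only compound 1 stands apart. No measured evidence on the reason for this is available. Still open, as far as these compounds go, is whether an amine, a carboxylic acid or a longer chain here stays with compound 3 or moves toward compound 1.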